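Methyl on the ring amine nitrogen: next step in the series

This account rests on a few compounds, and the source may have more. Where it says the series, first, only, none or still open, it means among the compounds named here.

For the measured compounds named here, compound 2 `Clc1ccc(Oc2ccc3nc(-c4ccc(OCCCN5CCNCC5)cc4)oc3c2)cc1` stands highest of the two numbers so far: in an assay on isolated protein for inhibition of advanced glycosylation end product-specific receptor (Homo sapiens), read by FRET, with stated times of 30 min and 1 h, tested at 4 uM (a lower number here means less inhibition, a higher number more inhibition at the concentration tested (going by the name of the read-out)), compound 2 gives 42.7%. Going by the values given here, compound 1 `N[C@@H]1CCN(CCCOc2ccc(-c3nc4ccc(Oc5ccc(Cl)cc5)cc4o3)cc2)C1` gives 19.6% in this assay; the single measured step, a number 23.1 percentage points higher from compound 1 to compound 2 (beyond the scatter), put piperazin-1-yl in place of 3-aminopyrrolidin-1-yl on a saturated chain carbon. Compound 3 `CN1CCN(CCCOc2ccc(-c3nc4ccc(Oc5ccc(Cl)cc5)cc4o3)cc2)CC1` differs from compound 2 by methyl in place of hydrogen on an amine nitrogen in a ring. Among the compounds with values here, no measured step bears on methyl in place of hydrogen on an amine nitrogen in a ring, so no step beyond the scatter is expected in this assay. Compound 3 is estimated at 40%, between 25% and 55%. The expected step is a number 2.7 percentage points lower from compound 2 to compound 3 (within the scatter), within the scatter.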

Compound 3, a percentage reported as inhibition, at one concentration (the size of the read-out at that concentration, not a potency): 24.3%
For compound 3 the middle estimate is 15.7 percentage points above the measured one; measured number outside the range, below it.
By their numbers in this assay, from the lowest: compounds 1 and 3 (each within the scatter of the next); then compound 2.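

On this ring amine nitrogen, in this assay, a single methyl is not a neutral change: the step is a number 18.4 percentage points lower from compound 2 to compound 3 (beyond the scatter) and removes the gain seen with piperazin-1-yl. Set against 3-aminopyrrolidin-1-yl, 4-methylpiperazin-1-yl shows a number 4.7 percentage points higher from compound 1 to compound 3 (within the scatter) and so gives no separation between these two amines. Nothing available accounts for the methyl step.

As far as these compounds go, it remains open whether ethyl or acetyl on this nitrogen would behave as methyl does. Also open, from the compounds shown here alone, is whether the methyl step persists with a longer chain between the ring and the oxygen.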